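The source may report more compounds than this note shows. Statements on the series, on what has been measured and on what is new or still open speak of the compounds shown alone.

In a functional assay on HeLa cells (Homo sapiens) for inhibition, read by MTT assay, with a stated time of 72 h (a lower number here means a stronger inhibitor, a higher number a weaker inhibitor), compound 1 (`COc1cc(NC(C)CCCNC(=O)Nc2ccc(Br)cc2)c2ncccc2c1`) gives 20000 nM. Compound 2 (`COc1cc(NC(C)CCCNC(=O)NNC(=O)Nc2ccc(F)cc2)c2ncccc2c1`) gives >= 250000 nM, which is a limit of the assay and not a number. Compound 3 (`COc1cc(NC(C)CCCNC(=O)NNC(=O)Nc2ccc(O)cc2)c2ncccc2c1`) gives 85000 nM, the higher of the two true numbers. Compound 4 (`COc1cc(NC(C)CCCNC(=O)Nc2ccc(O)cc2)c2ncccc2c1`) differs from it by 4-hydroxyphenyl in place of ((4-hydroxyphenyl)carbamoyl)amino on an amide-type nitrogen. The closest measured changes run the other way and also alter the ring substituent: a 4.3-fold higher number from compound 1 to compound 3 (0.63 log units; beyond the scatter), which is modest, and an at least 12-fold higher number from compound 1 to compound 2 (1.09 log units; beyond the scatter), which is large. A modest step to a lower number is therefore expected in this assay, with the expected change being a 3.9-fold lower number from compound 3 to compound 4 (0.59 log units; beyond the scatter). For compound 4 the estimated value is 22000 nM, within a range of 7000 nM to 70000 nM.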

Compound 4, half-maximal inhibitory concentration: 70000 nM
For compound 4 the middle estimate is 3.2-fold (0.50 log units) below the measured one; measured number inside the range.
By their numbers in this assay, from the lowest: compound 1; then compounds 4 and 3 (each within the scatter of the next). At a limit, above all of these: compound 2.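

In this assay, 4-hydroxyphenyl in place of ((4-hydroxyphenyl)carbamoyl)amino on an amide-type nitrogen, with the ring hydroxy kept, gives no change that stands out from the scatter: a 1.2-fold lower number from compound 3 to compound 4 (0.08 log units; within the scatter). Hydroxy in place of bromo on an aromatic carbon, now seen alone, gives a 3.5-fold higher number from compound 1 to compound 4 (0.54 log units; beyond the scatter). The remaining step starts from a limit of the assay and not a number: an at least 3.5-fold lower number from compound 2 to compound 4 (0.55 log units; beyond the scatter). Its limit is this one: the limit of >= 250000 nM in this assay, at which 1 of the 4 values shown sits.

From the compounds shown here alone, whether an amine or a carboxylic acid on that aromatic carbon would behave like hydroxy or bromo stays open. So does the effect of a longer chain on the amide-type nitrogen.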